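The source may report more compounds than this note shows. Statements on the series, on what has been measured and on what is new or still open speak of the compounds shown alone.

Of the compounds shown here, three built on one shared core have been tested in a functional assay on L6 cells (Rattus norvegicus) for inhibition; a higher number here means a weaker inhibitor, a lower number a stronger inhibitor. Compound 1 `CC(C)c1c(C(=O)N(C)Cc2ccccc2)nn(-c2ccc(F)cc2)c1CC[C@@H](O)C[C@@H](O)CC(=O)O` gives 2870 nM. Compound 2 `CC(C)c1c(C(=O)N(C)Cc2cccc(F)c2)nn(-c2ccc(F)cc2)c1CC[C@@H](O)C[C@@H](O)CC(=O)O` carries a fluoro in place of hydrogen on an aromatic carbon and gives 1900 nM; the step of a 1.5-fold lower number from compound 1 to compound 2 (0.18 log units; within the scatter) stays within the scatter of repeated measurements. Compound 3 `CC(C)c1c(C(=O)N2CCCC2c2ccccc2)nn(-c2ccc(F)cc2)c1OC[C@@H](O)C[C@@H](O)CC(=O)O` gives 4340 nM, the highest of the three numbers, although its gap to compound 1 is within the scatter and only its gap to compound 2 lies beyond it.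

Compound 4 `COCc1cccc(CNC(=O)c2nn(-c3ccc(F)cc3)c(OC[C@@H](O)C[C@@H](O)CC(=O)O)c2C(C)C)c1` differs from compound 3 in a single place: (3-(methoxymethyl)benzyl)amino in place of 2-phenylpyrrolidin-1-yl on a carbonyl carbon. Within the data shown here, no measured step covers such an exchange on the carbonyl carbon; the only measured step, a 1.5-fold lower number from compound 1 to compound 2 (0.18 log units; within the scatter), concerns a fluoro swap elsewhere and gives no guidance here. Compounds 1 and 2 carry benzyl groups on their amides too, yet they also differ from compound 3 elsewhere, so their numbers are only a loose pointer. The expectation is therefore a small change, a 1.6-fold lower number from compound 3 to compound 4 (0.19 log units; within the scatter), not clearly beyond the scatter. Compound 4 is estimated at 2800 nM, with a likely range from 1000 nM to 7000 nM.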

Compound 4, half-maximal inhibitory concentration: 3600 nM
The estimate for compound 4 lay 1.3-fold (0.11 log units) below the measured number; the range from low to high includes it.
By their numbers in this assay, from the lowest: compounds 2, 1, 4 and 3 (each within the scatter of the next, the first and the last beyond it).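

On the carbonyl carbon, (3-(methoxymethyl)benzyl)amino in place of 2-phenylpyrrolidin-1-yl gives a 1.2-fold lower number from compound 3 to compound 4 (0.08 log units; within the scatter) in this assay, so the two numbers cannot be told apart. Among these compounds, this is the first exchange at this place with a readable result: the entering group lacks the five-membered non-aromatic ring and adds a hydrogen-bond donor and a hydrogen-bond acceptor, yet the read-out does not separate the two compounds. No measurement here offers an explanation for this result.

Both groups are of similar size and each carries a six-membered aromatic ring, so a much smaller group on this carbonyl carbon, such as methylamino, remains untested among these compounds. On these data alone, it also remains open whether a carboxylic acid or an amine in place of the methoxymethyl would move the number.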